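Acetamido replacing dimethylamino on a shared core

The source may hold more compounds than are shown below. What is called first, only, known or untested is meant among the compounds shown, and "the series" means these compounds.

Compound 1 `CC(=O)Nc1ccc(NC(=O)c2cn(Cc3c(F)cccc3F)c3ccc(=O)[nH]c3c2=O)cc1`: 24 nM
Compound 2 `NS(=O)(=O)c1ccc(NC(=O)c2cn(Cc3c(F)cccc3F)c3ccc(=O)[nH]c3c2=O)cc1`: 34 nM
Compound 3 `CN(C)c1ccc(NC(=O)c2cn(Cc3c(F)cccc3Cl)c3ccc(=O)[nH]c3c2=O)cc1`: 39 nM

Three compounds share one core and differ in the group on the outer aromatic ring and in the halogens of the benzyl part. In an in vitro assay on Sf21 cells for inhibition of high affinity 3',5'-cyclic-AMP phosphodiesterase 7A (Homo sapiens), read by scintillation proximity assay, with a stated time of 30 min (on this read-out higher numbers stand for weaker inhibition and lower numbers for stronger inhibition), compound 1 gives 24 nM, compound 2 gives 34 nM and compound 3 gives 39 nM. Compound 3 carries the highest of the three numbers, yet its gaps to compound 2 and to compound 1 both lie within the scatter, so no order among them can be claimed.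

Compound 4 `CC(=O)Nc1ccc(NC(=O)c2cn(Cc3c(F)cccc3Cl)c3ccc(=O)[nH]c3c2=O)cc1` is not yet measured. It differs from compound 3 in one place: acetamido in place of dimethylamino on an aromatic carbon. Among the compounds with values here, the only measured step at that same position is a 1.4-fold higher number from compound 1 to compound 2 (0.15 log units; within the scatter), and it stays within the scatter. Within the data shown here, no measured pair exchanges dimethylamino for acetamido, so the step can only be judged indirectly. Compound 1, which already carries acetamido, gives 24 nM, a number that sits close to compound 3.

Compound 4 is therefore expected to show little change beyond the scatter, with an estimated step of a 1.4-fold lower number from compound 3 to compound 4 (0.14 log units; within the scatter) in this assay. The estimate for compound 4 is 28 nM, with a range from 12 nM to 65 nM.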

Compound 4, half-maximal inhibitory concentration: 17 nM
Estimate against measurement, compound 4: 1.6-fold (0.22 log units) above; the range from low to high includes it.
By their numbers in this assay, from the lowest: compounds 4, 1, 2 and 3 (each within the scatter of the next, the first and the last beyond it).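

Within the data shown here, this is the first direct look at the dimethylamino-to-acetamido exchange at this position, para to a large group, with the rest of the molecule unchanged. In this assay, acetamido in place of dimethylamino gives a 2.3-fold lower number from compound 3 to compound 4 (0.36 log units; beyond the scatter), a modest step but one that lies beyond the usual scatter, whereas the earlier exchange of acetamido for sulfamoyl, a 1.4-fold higher number from compound 1 to compound 2 (0.15 log units; within the scatter), did not, so this position can shift the number, though not with every exchange. The halogen change on the benzyl part, chloro in place of fluoro with acetamido held fixed, gives a 1.4-fold lower number from compound 1 to compound 4 (0.15 log units; within the scatter) and stays within the scatter, so this pair shows no clear effect of that exchange.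

The compounds shown leave open how a primary amine, a carboxylic acid or a longer acyl chain at the same place would compare with acetamido, and whether the dimethylamino-to-acetamido step would have the same size with two fluoro groups on the benzyl part. Nothing available here explains why the number moves with this exchange.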